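The compounds below may be only part of what the source reports. "The series", "measured", "known", "first", "only" and "open" are said of these compounds alone.

In a functional assay on MGC-803 cells (Homo sapiens) for cytotoxicity, read by MTT assay, with a stated time of 48 h (on this read-out higher numbers stand for weaker inhibition and lower numbers for stronger inhibition), three compounds have so far been measured. Compound 1, `CC1=NN(S(=O)(=O)c2ccc([N+](=O)[O-])cc2)C(c2cc(Br)cc(Br)c2O)C1`, gives 40100 nM in this assay. Compound 2, `CC(=O)Oc1ccccc1C1CC(C)=NN1C(=O)CN1CCC(C(C)=O)CC1`, gives 4120 nM in this assay. Compound 3, `O=C(CCl)N1N=C(c2cc3ccccc3oc2=O)CC1c1ccccc1`, holds the lowest number of the three, giving 2020 nM in this assay. Its nearest neighbour on this read-out is compound 2, whose number is higher by a margin beyond the usual scatter, and compound 1 lies much further away, also beyond the scatter.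

Compound 4, `CN1CCN(CC(=O)N2N=C(c3cc4ccccc4oc3=O)CC2c2ccccc2)CC1`, differs from compound 3 in a single place: 4-methylpiperazin-1-yl in place of chloro on a saturated chain carbon bound to a carbonyl carbon. Among the compounds with values here, no pair of measured compounds carries this same change, so there is no measured step to lean on. Within the data shown here, compound 2 is the only other measured compound whose carbonyl chain ends in a ring bearing nitrogen, and its value of 4120 nM stands close to that of compound 3, though its core is different and this is at best a loose guide.

The step of a 1.6-fold higher number from compound 3 to compound 4 (0.20 log units; within the scatter) in this assay is expected to be small, toward a somewhat higher number, and may not exceed the scatter. Compound 4 is estimated to give 3200 nM in this assay, within a range from 1000 nM to 10000 nM.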

Compound 4, half-maximal inhibitory concentration: 46100 nM
Compound 4: middle estimate off by 14-fold (1.16 log units), on the low side; the measured number lies above the stated range.
By their numbers in this assay, from the lowest: compound 3; then compound 2; then compounds 1 and 4 (each within the scatter of the next).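

In this assay, the first step measured at this place shows that the number is far from indifferent to what sits on the saturated chain carbon bound to a carbonyl carbon: a 23-fold higher number from compound 3 to compound 4 (1.36 log units; beyond the scatter), as a single chlorine atom gives way to the seven heavy atoms of 4-methylpiperazin-1-yl. Within the data shown here, the earlier compounds differ from one another in more than one place and offered no step, so this is the first reading of how far the number can move with the rest of the structure held fixed, and here the chloro compound holds by far the lower number. Nothing in the data given accounts for the size of this step.

Among these compounds, the single pair leaves open whether the rise belongs to the 4-methylpiperazin-1-yl ring as such or to the loss of chloro, since any replacement might have the same result. A dimethylamino group, a morpholine ring or a plain methyl on the same carbon would separate these readings, and whether any of them stays close to compound 3 or rises as compound 4 does remains an open question.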